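The source may report more compounds than this note shows. Statements on the series, on what has been measured and on what is new or still open speak of the compounds shown alone.

In a functional assay on HepG2 cells (Homo sapiens) for antiproliferative activity, read by MTT assay, with a stated time of 48 h (on this read-out lower numbers stand for stronger inhibition and higher numbers for weaker inhibition), the measured compounds read as follows:
Compound 1 (`CCN1C(=O)C(=O)c2cc(-c3ccc(OC)cc3)ccc21`) gives 4470 nM
Compound 2 (`COc1ccc(-c2ccc3c(c2)C(=O)C(=O)N3Cc2ccc(Cl)c(Cl)c2)cc1`) gives 990 nM
Compound 3 (`COc1ccc(-c2ccc3c(c2)C(=O)C(=O)N3Cc2ccc(Cl)cc2)cc1`) gives 250 nM

Compound 1 holds the highest of the three numbers. Compound 4 (`COc1ccc(-c2ccc3c(c2)C(=O)C(=O)N3Cc2cccc(Cl)c2)cc1`) is still unmeasured and differs from compound 1 by 3-chlorophenyl in place of methyl on a saturated chain carbon bound to an amide-type nitrogen in a ring. For the measured compounds named here, two steps bear on it. With 4-chlorophenyl in place of methyl there was an 18-fold lower number from compound 1 to compound 3 (1.25 log units; beyond the scatter) and the step was large, while with 3,4-dichlorophenyl in place of methyl there was a 4.5-fold lower number from compound 1 to compound 2 (0.65 log units; beyond the scatter) and the step was modest. In this assay a step to a lower number, beyond the scatter and of modest to large size, is therefore expected. The estimate means an 8.9-fold lower number from compound 1 to compound 4 (0.95 log units; beyond the scatter) as the expected step. Compound 4 is estimated at 500 nM with 170 nM to 1500 nM as the expected range.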

Compound 4, half-maximal inhibitory concentration: 320 nM
Compound 4: middle estimate off by 1.6-fold (0.19 log units), on the high side; the range from low to high includes it.
By their numbers in this assay, from the lowest: compounds 3 and 4 (each within the scatter of the next); then compound 2; then compound 1.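

In this assay, 3-chlorophenyl in place of methyl also gives a large step, a 14-fold lower number from compound 1 to compound 4 (1.15 log units; beyond the scatter), and exchanging 4-chlorophenyl for 3-chlorophenyl makes no real difference, with a 1.3-fold higher number from compound 3 to compound 4 (0.11 log units; within the scatter). The higher number of compound 2 now stands against both single-chloro compounds, since removing the other chloro also counts, here as a 3.1-fold lower number from compound 2 to compound 4 (0.49 log units; beyond the scatter). Nothing available gives a reason for these steps. From the compounds shown here alone, whether a plain phenyl, or bromo or a nitrile in place of the chloro, would hold the number at this level stays open.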